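The compounds below may be only part of what the source reports. "The series", "measured", "known", "first", "only" and "open" are said of these compounds alone.

Measured so far in an ADME assay on MT2 cells (Homo sapiens) for cytotoxicity, with a stated time of 5 days; a lower number here means that less compound is tolerated, a higher number that more compound is tolerated:
compound 1 `Cc1c(Oc2ccccc2OCCn2ccc(=O)[nH]c2=O)cc(N(C)C(=O)CCl)c2ccc(C#N)cc12` gives 32000 nM;
compound 2 `C=CC(=O)Nc1cc(Oc2ccccc2OCCn2ccc(=O)[nH]c2=O)c(C)c2cc(C#N)ccc12` gives 11000 nM.

Compound 2 stands lowest of the two numbers, with compound 1 the nearest at a 2.9-fold lower number from compound 1 to compound 2 (0.46 log units; beyond the scatter) away, a modest step that lies beyond the scatter. Compound 3 `C=CC(=O)N(C)c1cc(Oc2ccccc2OCCn2ccc(=O)[nH]c2=O)c(C)c2cc(C#N)ccc12` is not yet measured. It differs from compound 2 by methyl in place of hydrogen on an amide-type nitrogen, the same difference read one bond further out being (vinylcarbonyl)amino to methyl(vinylcarbonyl)amino. Going by the values given here, only one measured step bears on this change, and it does so only in part: the step from compound 1 to compound 2 removes the methyl from the amide-type nitrogen while also exchanging the acyl group, so the share of the methyl alone in a 2.9-fold lower number from compound 1 to compound 2 (0.46 log units; beyond the scatter) is not separable. Compound 3 is therefore expected to sit between the two measured values, a step of a 1.5-fold higher number from compound 2 to compound 3 (0.19 log units; within the scatter) in this assay, giving an estimate for compound 3 of 17000 nM with a range of 6000 nM to 45000 nM.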

Compound 3, half-maximal cytotoxic concentration: 32000 nM
Compound 3: the middle estimate sits 1.9-fold (0.27 log units) below what was measured, within the range that was stated.
By their numbers in this assay, from the lowest: compound 2; then compounds 1 and 3 (each within the scatter of the next).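

In this assay, the methyl on the amide-type nitrogen can now be read alone: methyl in place of hydrogen gives a 2.9-fold higher number from compound 2 to compound 3 (0.46 log units; beyond the scatter). With that methyl kept, vinyl in place of chloromethyl on the carbonyl carbon gives no change at the digits printed from compound 1 to compound 3 (within the scatter), so across these three compounds the whole of a 2.9-fold lower number from compound 1 to compound 2 (0.46 log units; beyond the scatter) goes with the methyl and no separate share shows for the acyl exchange. Nothing available explains why the number moves with this methyl.

Open, on these data alone, is whether an ethyl or a longer chain on the same nitrogen would follow the methyl or depart from it. Also open, as far as these compounds go, is whether vinyl and chloromethyl on the carbonyl carbon would still read alike with hydrogen rather than methyl on that nitrogen.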